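A few compounds are considered here, and "the series" means these few. Any claim that something is new, unique, unknown or untested is made for them only; others in the source may bear on it.

The account concerns three compounds on a shared core. Compound 1 `CCCCCc1ccc(Nc2ccc3c(c2)C(=O)N(C2CCC(=O)NC2=O)C3=O)cc1` and compound 2 `CN(c1ccccc1)c1ccc2c(c1)C(=O)N(C1CCC(=O)NC1=O)C2=O` have been tested in an assay on FRT-Jurkat cells for inhibition of nuclear factor NF-kappa-B complex (Homo sapiens), read by flow cytometry, with a stated time of 24 h, tested at 10 uM; a lower number here means less inhibition, a higher number more inhibition at the concentration tested (going by the name of the read-out). In this assay compound 1 gives 12%, and in this assay compound 2 gives -2%. Compound 2 stands lowest of the two numbers; its nearest neighbour, compound 1, lies higher by an amount beyond the usual scatter.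

Compound 3 `Cc1ccc(Nc2ccc3c(c2)C(=O)N(C2CCC(=O)NC2=O)C3=O)cc1` has not yet been measured. It differs from compound 2 in one place: (4-methylphenyl)amino in place of methyl(phenyl)amino on an aromatic carbon. The two compounds are made of the same atoms, joined differently, and the group that enters counts one hydrogen-bond donor where the group that leaves counts none.

Among the measured compounds shown here, no step between measured compounds is available as a guide; the expectation rests on the two values and on the structural change. Compound 1, whose group at that position likewise counts one hydrogen-bond donor, gives 12%, above compound 2. Compound 3 is expected to show an upward step of a number 10 percentage points higher from compound 2 to compound 3 (within the scatter), close to the edge of the scatter. For compound 3 the estimate in this assay is 8%, with a range from -8% to 22%.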

Compound 3, a percentage reported as inhibition, at one concentration (the size of the read-out at that concentration, not a potency): 5%
Estimate against measurement, compound 3: 3 percentage points above, and the stated range covers the measured number.
By their numbers in this assay, from the lowest: compounds 2, 3 and 1 (each within the scatter of the next, the first and the last beyond it).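

In this assay, (4-methylphenyl)amino in place of methyl(phenyl)amino on an aromatic carbon gives a number 7 percentage points higher from compound 2 to compound 3 (within the scatter), so this exchange of groups made of the same atoms, in which the entering group counts one hydrogen-bond donor and the leaving group none, does not shift the read-out beyond the scatter. At the far end of the same substituent, hydrogen in place of butyl on a saturated chain carbon bound to an aromatic carbon gives a number 7 percentage points lower from compound 1 to compound 3 (within the scatter), so in this assay the shorter chain cannot be told apart from the longer one. Nothing on hand explains either step.

The compounds shown leave open whether a carboxylic acid, an amine or a methoxy group in place of the methyl of compound 3 would move the read-out beyond the scatter. They also leave open how a propyl chain at that spot would read, and whether a plain phenylamino group, with no methyl on either the ring or the nitrogen, would fall in line with compound 2 and compound 3.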